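Amide nitrogen: acetylpyrrolidinyl in place of acetylmorpholinylmethyl

The source may report more compounds than this note shows. Statements on the series, on what has been measured and on what is new or still open speak of the compounds shown alone.

Compound 2 `CC(=O)N1CCOC(CNC(=O)c2ccncc2Nc2cc(-c3ccc4ccn(C)c4c3)c3nccnc3c2)C1` is one of two measured members of this series. In an assay on lysate for inhibition of 6-phosphofructo-2-kinase/fructose-2,6-bisphosphatase 3 (Homo sapiens), with stated times of 0.5 min and 45 min (on this read-out higher numbers stand for weaker inhibition and lower numbers for stronger inhibition), compound 2 gives only a limit, > 100000 nM. Compound 1 `Cn1cc(NC(=O)c2ccncc2Nc2cc(-c3ccc4ccn(C)c4c3)c3nccnc3c2)cn1` in this assay gives 26500 nM. Going by the values given here, the single measured step, an at least 3.7-fold higher number from compound 1 to compound 2 (0.57 log units; beyond the scatter), ends at the limit of > 100000 nM in this assay, at which 1 of the 2 values shown sits, so its full size is unknown beyond being at least modest.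

Compound 3 `CC(=O)N1CCC(NC(=O)c2ccncc2Nc2cc(-c3ccc4ccn(C)c4c3)c3nccnc3c2)C1` differs from compound 2 by 1-acetylpyrrolidin-3-yl in place of (4-acetylmorpholin-2-yl)methyl on an amide-type nitrogen. No measured step covers this change; the one step shown concerns the exchange of 1-methyl-1H-pyrazol-4-yl for (4-acetylmorpholin-2-yl)methyl on the same amide-type nitrogen and says nothing about a pyrrolidine in that place. With compound 2 at a limit, a step in either direction cannot be sized from the numbers given. Compound 3 is expected to remain near that limit, and the estimated step of a number no higher from compound 2 to compound 3 (the limit leaves the size open) carries little weight. In this assay compound 3 is estimated at 100000 nM, within 25000 nM to 400000 nM, with a real chance that only a limit is reported once more.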

Compound 3, half-maximal inhibitory concentration: > 100000 nM
Compound 3 was reported as a limit; the forecaster's own chance of this, stated with the estimate: 60%; the middle value sits exactly at the limit.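

In this assay compound 3 gives > 100000 nM, which is a limit of the assay and not a number. From the compounds shown here alone, a second replacement of 1-methyl-1H-pyrazol-4-yl on the amide-type nitrogen gives an at least 3.7-fold higher number from compound 1 to compound 3 (0.57 log units; beyond the scatter), so the weaker inhibition first seen with (4-acetylmorpholin-2-yl)methyl is not confined to that group, and its full size remains unknown for both compounds. The step from compound 2 to compound 3 cannot be read, and the two acetylated groups cannot be ranked, because both compounds stand at the same limit: the limit of > 100000 nM in this assay, at which 2 of the 3 values shown sit.

The compounds shown leave open whether the weaker inhibition follows from losing the 1-methyl-1H-pyrazol-4-yl group or from the acetyl group shared by compound 2 and compound 3. A free secondary amine such as pyrrolidin-3-yl, without the acetyl, or another small heteroaryl such as 1-methyl-1H-imidazol-4-yl on the same amide-type nitrogen would help separate these two readings, provided that the value falls short of the limit in this assay.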